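The compounds below may be only part of what the source reports. "The series", "measured", "known", "first", "only" and "open" are said of these compounds alone.

Of the compounds shown here, three have so far been tested for their power to stop the growth of HEp-2 cells. In a functional assay on HEp-2 cells (Homo sapiens) for cytotoxicity, read by sulforhodamine B assay, with a stated time of 48 h (a lower number here means a stronger inhibitor, a higher number a weaker inhibitor), compound 1 `COc1cc(C2CC(c3ccc(Br)cc3)=NN2C(C)=O)cc(OC)c1OC` gives 4530 nM, compound 2 `CC(=O)N1N=C(c2ccco2)CC1c1ccc([N+](=O)[O-])cc1` gives 21800 nM, and compound 3 `CC(=O)N1N=C(c2ccco2)CC1c1ccc(Br)cc1` gives 51200 nM. Compound 3 thus has the highest number of the three, meaning the weakest inhibition seen yet: compound 2 stands nearest to it, and compound 1 lies furthest away with a much lower number. Compound 2 and compound 3 share one core and differ at a single aromatic carbon, and there a 2.3-fold higher number from compound 2 to compound 3 (0.37 log units; beyond the scatter) was seen.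

Compound 4 `CC(=O)N1N=C(c2ccco2)CC1c1ccc(Cl)cc1` is the next step from compound 3. The change is chloro in place of bromo on an aromatic carbon. Among the measured compounds shown here, no measured pair exchanges one halogen for another, so the only step on this core, from compound 2 to compound 3, concerns a different kind of group and gives no direct guide. Swapping bromo for chloro is a small change, and in this assay it is expected to leave the number close to where compound 3 stands, with no step beyond the scatter. For compound 4 the estimate is therefore 55000 nM, within a range from 25000 nM to 120000 nM. The expected step is a 1.1-fold higher number from compound 3 to compound 4 (0.03 log units; within the scatter).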

Compound 4, half-maximal inhibitory concentration: 57400 nM
Compound 4: the middle estimate sits 1.0-fold (0.02 log units) below what was measured, and the stated range covers the measured number.
By their numbers in this assay, from the lowest: compound 1; then compound 2; then compounds 3 and 4 (each within the scatter of the next).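

In this assay, trading one halogen for the other at this aromatic carbon leaves the reading unchanged within the usual scatter, with a 1.1-fold higher number from compound 3 to compound 4 (0.05 log units; within the scatter) as the step, so bromo and chloro cannot be told apart here. Chloro in place of nitro gives a 2.6-fold higher number from compound 2 to compound 4 (0.42 log units; beyond the scatter) and so falls on the same side as bromo, which gave a 2.3-fold higher number from compound 2 to compound 3 (0.37 log units; beyond the scatter) on the same core; on this core, both halogens therefore give weaker inhibition than nitro, by a modest margin that now rests on two separate compounds rather than one. No independent measurement is available to explain why these groups behave as they do.

From the compounds shown here alone, three groups at one position give only a narrow view, so it remains open how this aromatic carbon would respond to an amine, a carboxylic acid or a plain hydrogen. Going by these compounds, it is also open whether the match between bromo and chloro would hold on the core of compound 1, which carries bromo on a different ring arrangement and has no chloro partner for a direct comparison.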